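This account rests on a few compounds, and the source may have more. Where it says the series, first, only, none or still open, it means among the compounds named here.

In an ADME assay on isolated protein for inhibition of Amine oxidase [flavin-containing] A (Homo sapiens), read by fluorescence and Amplex Red, with stated times of 15 min and 20 min (on this read-out lower numbers stand for stronger inhibition and higher numbers for weaker inhibition), compound 3 `C#CCN(CCCCOc1ccc2ccc(=O)oc2c1)Cc1ccc(C)cc1` gives 94500 nM, the highest of the three numbers shown, though each step to the other two is within the scatter: compound 1 `C#CCN(CCCCOc1ccc2ccc(=O)oc2c1)Cc1ccc(OC)cc1` gives 54500 nM and compound 2 `C#CCN(CCCCOc1ccc2ccc(=O)oc2c1)Cc1cccc(OC)c1` gives 78600 nM. Compound 4 `C#CCN(CCCCOc1ccc2ccc(=O)oc2c1)Cc1ccccc1` differs from compound 3 by hydrogen in place of methyl on an aromatic carbon. Within the data shown here, no measured pair exchanges methyl for hydrogen. The step that comes closest, a 1.7-fold higher number from compound 1 to compound 3 (0.24 log units; within the scatter), alters the group on that aromatic carbon, while a 1.4-fold higher number from compound 1 to compound 2 (0.16 log units; within the scatter) and a 1.2-fold higher number from compound 2 to compound 3 (0.08 log units; within the scatter) move the group to another ring carbon. All three lie within the scatter, so in this assay no step beyond the scatter is expected from compound 3 to compound 4, the estimated step being a 1.1-fold lower number from compound 3 to compound 4 (0.05 log units; within the scatter). Compound 4 is therefore expected to give 85000 nM, between 40000 nM and 180000 nM.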

Compound 4, half-maximal inhibitory concentration: 89400 nM
For compound 4 the middle estimate is 1.1-fold (0.02 log units) below the measured one; the range from low to high includes it.
By their numbers in this assay, from the lowest: compounds 1, 2, 4 and 3 (each within the scatter of the next).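

In this assay, among these compounds, hydrogen in place of methyl gives a 1.1-fold lower number from compound 3 to compound 4 (0.02 log units; within the scatter), the first direct reading of this exchange on the aromatic carbon para to a large group. Hydrogen in place of methoxy reads the same way, with a 1.1-fold higher number from compound 2 to compound 4 (0.06 log units; within the scatter) and a 1.6-fold higher number from compound 1 to compound 4 (0.21 log units; within the scatter), so hydrogen, methyl and methoxy on this ring cannot be told apart across these four compounds. Nothing measured here bears on why.

From the compounds shown here alone, it remains open whether an amine or a carboxylic acid on this carbon would give a step beyond the scatter. The same question stands for a longer chain in place of the methyl.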